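The source may report more compounds than this note shows. Statements on the series, on what has been measured and on what is new or still open speak of the compounds shown alone.

Compound 1 `Cn1c(-c2ccccc2)nc2c(NC3CCCCC3)ncnc21` gives 2370 nM in an assay on CHO cells for displacement of a labelled ligand from adenosine receptor A3 (Homo sapiens), read by scintillation counting, with a stated time of 3 h; a higher number here means a weaker inhibitor, a lower number a stronger inhibitor. Of the three numbers in hand this is the highest one: compound 2 `CCCn1c(-c2ccccc2)nc2c(NC3CCCCC3)ncnc21` gives 2360 nM in this assay, which is within the usual scatter of compound 1, and compound 3 `Cc1cccc(-c2nc3c(NC4CCCC4)ncnc3n2C)c1` gives 510 nM, clearly lower. Compound 4 `Cn1c(-c2ccccc2)nc2c(NC3CCCC3)ncnc21` has not yet been measured. It differs from compound 1 in a single place: cyclopentyl in place of cyclohexyl on a nitrogen on an aromatic ring. Among the compounds with values here, no measured step covers this change on its own. Within the data shown here, the only measured step, a 1.0-fold lower number from compound 1 to compound 2 (0.00 log units; within the scatter), concerns ethyl in place of hydrogen on a saturated chain carbon bound to an aromatic nitrogen and says nothing about the ring on the nitrogen. Compound 3 does carry a cyclopentyl group, but it differs from compound 1 in a second place as well, so its value is only a loose hint that the cyclopentyl may go with a lower number. A moderate fall is therefore expected, with wide uncertainty. The expected step is a 2.4-fold lower number from compound 1 to compound 4 (0.37 log units; beyond the scatter). Compound 4 is estimated at 1000 nM, within a range from 350 nM to 2800 nM.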

Compound 4, inhibition constant: 846 nM
Estimate against measurement, compound 4: 1.2-fold (0.07 log units) above; measured number inside the range.
By their numbers in this assay, from the lowest: compounds 3 and 4 (each within the scatter of the next); then compounds 2 and 1 (each within the scatter of the next).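

Replacing cyclohexyl with cyclopentyl on this nitrogen gives a 2.8-fold lower number from compound 1 to compound 4 (0.45 log units; beyond the scatter) in this assay, the first single change shown here that moves the number beyond the scatter. The second comparison, a 1.7-fold higher number from compound 3 to compound 4 (0.22 log units; within the scatter), shows that hydrogen in place of methyl on the aromatic carbon has no effect that can be told apart from the scatter, at least with cyclopentyl on the nitrogen. No outside evidence is available to explain the cyclopentyl step.

On these data alone, only these two saturated rings have been compared at this position, so it remains open how a cyclobutyl or cycloheptyl ring, or an open chain such as isopropyl, would behave there. It is also unknown whether a hydroxyl or an amine on the ring would be tolerated, or whether the cyclopentyl step would hold with other groups on the shared core.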